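A few compounds are considered here, and "the series" means these few. Any claim that something is new, unique, unknown or untested is made for them only; others in the source may bear on it.

Measured so far in a functional assay on HeLa cells (Homo sapiens) for inhibition, read by sulforhodamine B assay, with a stated time of 48 h; a higher number here means a weaker inhibitor of growth, a lower number a stronger inhibitor of growth:
- compound 1, `CC(=O)OC/C(=C\c1ccc(Cl)cc1)C(=O)c1ccccc1`: 3200 nM
- compound 2, `CC(=O)OC/C(=C\c1ccc(Cl)cc1)C(=O)c1ccc(Cl)cc1`: 19000 nM
- compound 3, `CC(=O)OC/C(=C/c1ccccc1Cl)C(=O)c1ccccc1`: 24000 nM

Compound 1 and compound 3 have the same atoms joined differently; the difference between the two cores is not broken down here. Compound 3 and compound 2 give numbers within the scatter of each other, and compound 3 is beyond the scatter from compound 1.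

Compound 2 differs from compound 1 by chloro in place of hydrogen on an aromatic carbon. The resulting step is a 5.9-fold higher number from compound 1 to compound 2 (0.77 log units; beyond the scatter).

Compound 4, `CC(=O)OC/C(=C/c1ccc(Cl)cc1Cl)C(=O)c1ccccc1`, is not yet measured. It differs from compound 3 by chloro in place of hydrogen on an aromatic carbon. This is the same kind of change as that from compound 1 to compound 2, not the same: in compound 4 the entering chloro sits meta to a chloro group as well as para to a large group, whereas in compound 2 it sits only para to a large group.

For compound 4 in this assay the expected step is a 2.1-fold higher number from compound 3 to compound 4 (0.32 log units; beyond the scatter), placed beside a 5.9-fold higher number from compound 1 to compound 2 (0.77 log units; beyond the scatter); the expectation rests on that earlier step and on compound 3 starting at 24000 nM, with some allowance for the differing surroundings. Compound 4 is therefore estimated at 50000 nM, within 15000 nM to 160000 nM.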

Compound 4, concentration for 50% growth inhibition: 22000 nM
Compound 4: the middle estimate sits 2.3-fold (0.36 log units) above what was measured, within the range that was stated.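

In this assay, chloro in place of hydrogen on an aromatic carbon gives a 1.1-fold lower number from compound 3 to compound 4 (0.04 log units; within the scatter), so on this core the change leaves the number within the scatter, and the size of the step does not carry over from the other core: the same change on two cores in this assay, a 5.9-fold higher number (0.77 log units; beyond the scatter) from compound 1 to compound 2 and a 1.1-fold lower number (0.04 log units; within the scatter) from compound 3 to compound 4, 6.5-fold (0.81 log units) apart, beyond the scatter of two such steps Within this series, then, a step read on one core cannot be assumed on the other. It does not show what sets the two steps apart: in compound 4 the entering chloro sits meta to a chloro group as well as para to a large group, in compound 2 only para to a large group, and with one pair per core, this difference in surroundings cannot be separated from the rest of the difference between the cores.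

Open, going by these compounds, is whether a group other than chloro, such as methoxy or a nitrile, would behave alike on both cores. Also open, on these data alone, is how the numbers respond when the acetate ester gives way to a free alcohol or an amine.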